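From Bromo to Fluoro on an Aromatic Carbon

The source may hold more compounds than are shown below. What is called first, only, known or untested is meant among the compounds shown, and "the series" means these compounds.

Compound 1 `CC(c1ccc(-c2ccccc2)c(F)c1)c1nnc2n1N=C(c1ccc(OC(F)(F)F)cc1)CS2` gives 8400 nM
Compound 2 `CC(C)Cc1ccc(C(C)c2nnc3n2N=C(c2ccc(Br)cc2)CS3)cc1` gives 4900 nM

Among the measured compounds shown here, both numbers come from a functional assay on Huh-7 cells (Homo sapiens) for inhibition, read by sulforhodamine B assay, with a stated time of 72 h (on this read-out lower numbers stand for stronger inhibition and higher numbers for weaker inhibition), and they are the only measurements available so far. Compound 2 stands at 4900 nM and compound 1 at 8400 nM, so the two lie within the usual scatter of each other and cannot be ranked.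

Compound 3 `CC(C)Cc1ccc(C(C)c2nnc3n2N=C(c2ccc(F)cc2)CS3)cc1` has not yet been measured. It differs from compound 2 by fluoro in place of bromo on an aromatic carbon on an aromatic carbon of a six-membered aromatic ring of carbon only, para to a large group, so that 4-bromophenyl becomes 4-fluorophenyl. For the measured compounds named here, no measured pair shows this exchange, and the data offer no direct guide to its size. The expectation therefore starts from compound 2 at 4900 nM and allows a wide range on both sides. The expected change is a 1.2-fold higher number from compound 2 to compound 3 (0.09 log units; within the scatter) and this estimate stays within the scatter, leaning only slightly towards weaker inhibition. Compound 3 is expected at 6000 nM within an estimated range of 2500 nM to 14000 nM.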

Compound 3, half-maximal inhibitory concentration: 7800 nM
Estimate against measurement, compound 3: 1.3-fold (0.11 log units) below, within the range that was stated.
By their numbers in this assay, from the lowest: compounds 2, 3 and 1 (each within the scatter of the next).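

In this assay, fluoro in place of bromo on an aromatic carbon, para to a large group, gives a 1.6-fold higher number from compound 2 to compound 3 (0.20 log units; within the scatter). This is the only pair shown that differs in one place, and it shows that 4-bromophenyl and 4-fluorophenyl cannot be told apart at this position, with the rest of the structure held the same. The read-out therefore gives no sign that this exchange of one halogen for the other matters here, and no separate measurement is available to explain the result.

The compounds shown leave open whether a group other than these two halogens at this place, such as a nitrile, a methoxy group, an amine or a carboxylic acid, or simply hydrogen, would move the number beyond the scatter. Going by these compounds, compound 1 carries trifluoromethoxy on this ring but also differs from compound 2 and compound 3 elsewhere, so it cannot settle that question, and whether the exchange from bromo to fluoro would give the same result alongside the other substituents of compound 1 also remains open.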